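Removing the methoxy group from compound 2

The source may hold more compounds than are shown below. What is called first, only, known or untested is meant among the compounds shown, and "the series" means these compounds.

Readings so far in a functional assay on MDA-MB-231 cells (Homo sapiens) for inhibition, read by sulforhodamine B assay, with a stated time of 48 h, tested at 10 uM (on this read-out lower numbers stand for less inhibition of growth and higher numbers for more inhibition of growth at the one concentration tested), for the measured compounds
- compound 1 `C/C(=N\O)c1ccc(NC(=O)Cn2nc(-c3ccc(Cl)cc3)nc2N)cc1` gives 17.4%
- compound 2 `COc1ccc(-c2nc3sc(-c4ccccc4)cn3n2)cc1` gives 53%
- compound 3 `COc1cc(-c2nc3sc(-c4ccccc4)cn3n2)cc(OC)c1OC` gives 41%

Compound 2 stands highest of the three, and both compound 3 and compound 1 lie below it by margins beyond the scatter. The next compound to read is compound 4 `c1ccc(-c2nc3sc(-c4ccccc4)cn3n2)cc1` in this assay as well. Against compound 2 the change is hydrogen in place of methoxy on an aromatic carbon and amounts to hydrogen in place of methoxy on an aromatic carbon, para to a large group.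

Among the measured compounds shown here, no measured pair isolates this change, so the data give only an indirect guide. With compound 2 at 53% and compound 3 at 41% on the shared core, a reading near these two seems likely. The expected change is a number 8 percentage points lower from compound 2 to compound 4 (within the scatter) as a modest downward step, probably within the scatter. The estimated value for compound 4 is 45% on this read-out. The estimated range for compound 4 runs from 28% to 62% in this assay.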

Compound 4, percent growth inhibition at one concentration: 35%
The estimate for compound 4 lay 10 percentage points above the measured number; the measured number falls inside the stated range.
By their numbers in this assay, from the lowest: compound 1; then compounds 4 and 3 (each within the scatter of the next); then compound 2.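

In this assay, among the compounds shown here, the change at this position reads as a number 18 percentage points lower from compound 2 to compound 4 (beyond the scatter) and is the first pair on the shared core to isolate it. The methoxy group on this aromatic carbon, para to a large group, therefore counts in this read-out: on this core, growth inhibition at the one concentration tested is higher with methoxy than with hydrogen, though this rests on a single pair. Nothing at hand gives a measured reason for the size or direction of this step.

As far as these compounds go, whether the gain is specific to methoxy or would also appear with another group at this place remains open. A hydroxyl group, an ethoxy group or a chlorine atom on the same carbon would each test that, and how far the step carries over to other substituents on the shared core is also unresolved.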